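Moving One Methoxy Group: From Compound 3 to Compound 4

The compounds below may be only part of what the source reports. "The series", "measured", "known", "first", "only" and "open" are said of these compounds alone.

- compound 1 `COc1cccc(/C=C2\CCC/C(=C\c3cccc(Br)c3)C2=O)c1OC`: 8800 nM
- compound 2 `COc1ccccc1/C=C1\CCC/C(=C\c2cccc(OC)c2OC)C1=O`: > 20000 nM
- compound 3 `COc1cccc(/C=C2\CCC/C(=C\c3cccc(OC)c3OC)C2=O)c1`: 7000 nM

In a functional assay on SW-620 cells (Homo sapiens) for cytotoxicity, read by MTT assay, with a stated time of 72 h (a lower number here means a stronger inhibitor, a higher number a weaker inhibitor), compound 3 gives 7000 nM. It cannot be told apart from compound 1, as the data show a 1.3-fold lower number from compound 1 to compound 3 (0.10 log units; within the scatter). Compound 2 gives > 20000 nM, which is a limit of the assay. Against that limit, the data show an at least 2.8-fold lower number from compound 2 to compound 3 (0.45 log units; beyond the scatter).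

Compound 4 `COc1ccc(/C=C2\CCC/C(=C\c3cccc(OC)c3OC)C2=O)cc1` keeps the shared core of compound 3 and changes in one place: 4-methoxyphenyl in place of 3-methoxyphenyl on a double-bonded chain carbon bound to a double-bonded ring carbon. Among the compounds with values here, no measured compound carries the 4-methoxyphenyl group, so the evidence is indirect. The exchange most like this one is an at least 2.8-fold lower number from compound 2 to compound 3 (0.45 log units; beyond the scatter), and it shows that this site can respond to where the methoxy sits. The exchange an at least 2.2-fold higher number from compound 1 to compound 2 (0.35 log units; beyond the scatter) points the same way. Neither step gives a direction for the new group, so only a small rise is expected. The expected change is a 1.4-fold higher number from compound 3 to compound 4 (0.15 log units; within the scatter). Compound 4 is estimated at 10000 nM, with an expected range of 4000 nM to 20000 nM.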

Compound 4, half-maximal inhibitory concentration: 13600 nM
The estimate for compound 4 lay 1.4-fold (0.13 log units) below the measured number; the measured number falls inside the stated range.
By their numbers in this assay, from the lowest: compounds 3, 1 and 4 (each within the scatter of the next). At a limit, above all of these: compound 2.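

In this assay, the exchange of 3-methoxyphenyl for 4-methoxyphenyl gives a 1.9-fold higher number from compound 3 to compound 4 (0.29 log units; within the scatter), so this move of the methoxy group does not separate the two compounds, whereas the earlier exchange of 2-methoxyphenyl for 3-methoxyphenyl gave an at least 2.8-fold lower number from compound 2 to compound 3 (0.45 log units; beyond the scatter). At this place on the double-bonded chain carbon, the 4-methoxyphenyl group also cannot be told apart from the 3-bromophenyl group: a 1.5-fold higher number from compound 1 to compound 4 (0.19 log units; within the scatter). The remaining step, an at least 1.4-fold lower number from compound 2 to compound 4 (0.16 log units; that floor lies within the scatter), has a floor within the scatter, and it rests on a value that is a limit: the limit of > 20000 nM in this assay, at which 1 of the 4 values shown sits.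

From the compounds shown here alone, whether the 2-methoxyphenyl and 4-methoxyphenyl groups truly differ therefore stays open. Also open, going by these compounds, is how a hydroxyl group, an amine or a carboxylic acid on the phenyl ring at this place would read in this assay.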